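A few compounds are considered here, and "the series" means these few. Any claim that something is new, unique, unknown or untested is made for them only; others in the source may bear on it.

Measured compounds:

compound 1 `COc1cccc(/C=C2\CCC/C(=C\c3cccc(OC)c3OC)C2=O)c1` — 9900 nM in a functional assay on HT-1080 cells (Homo sapiens) for cytotoxicity, read by MTT assay, with a stated time of 72 h; a higher number here means a weaker inhibitor, a lower number a stronger inhibitor
compound 2 `COc1cc(/C=C2\CCC/C(=C\c3cccc(OC)c3OC)C2=O)cc(OC)c1` — 4500 nM
compound 3 `COc1cc(/C=C2\CCC/C(=C\c3ccc(OC)c(OC)c3)C2=O)cc(OC)c1` — 2600 nM

From compound 1 to compound 2 the change is methoxy in place of hydrogen on an aromatic carbon, and the step is a 2.2-fold lower number from compound 1 to compound 2 (0.34 log units; beyond the scatter). Compound 3 `COc1cc(/C=C2\CCC/C(=C\c3ccc(OC)c(OC)c3)C2=O)cc(OC)c1` carries a core whose difference from that of compound 1 is not broken down here; compound 3 gives 2600 nM, the lowest of the three numbers, within the scatter of compound 2.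

Compound 4 `COc1ccc(/C=C2\CCC/C(=C\c3cc(OC)c(OC)c(OC)c3)C2=O)cc1OC` is not yet measured. Against compound 3 it shows (methoxy in place of hydrogen on an aromatic carbon). This is the same kind of change as from compound 1 to compound 2, not the same: there the entering methoxy stood meta to a large group and meta to a methoxy group, here it stands ortho to two methoxy groups and para to a large group. Resting on compound 1 to compound 2 giving a 2.2-fold lower number from compound 1 to compound 2 (0.34 log units; beyond the scatter), a comparable but somewhat smaller step a 1.4-fold lower number from compound 3 to compound 4 (0.16 log units; within the scatter) is expected for compound 4. Compound 4 is estimated at 1800 nM, between 800 nM and 4500 nM.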

Compound 4, half-maximal inhibitory concentration: 1100 nM
The estimate for compound 4 lay 1.6-fold (0.21 log units) above the measured number, and the stated range covers the measured number.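

In this assay, methoxy in place of hydrogen on an aromatic carbon gives a 2.4-fold lower number from compound 3 to compound 4 (0.37 log units; beyond the scatter). The step carries over from one core to the other with no difference in size beyond the scatter: the same change on two cores in this assay, a 2.2-fold lower number (0.34 log units; beyond the scatter) from compound 1 to compound 2 and a 2.4-fold lower number (0.37 log units; beyond the scatter) from compound 3 to compound 4, 1.1-fold (0.03 log units) apart, within the scatter of two such steps. Going by these compounds alone, this rests on only two pairs, with the entering methoxy in a different place in each, so it supports carrying the change between these two cores in this assay but gives neither a general rule for the series nor a reason for the step.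

Going by these compounds, whether an ethoxy group, a longer chain, a halogen or an amine on the same aromatic carbon would give a similar step remains open. Also open, on these data alone, is whether the methoxy step holds on any other core.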